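A methyl on the ring nitrogen, tested in cells

A few compounds are considered here, and "the series" means these few. Any claim that something is new, unique, unknown or untested is made for them only; others in the source may bear on it.

Measured compounds in a functional assay on A549 cells (Homo sapiens) for cytotoxicity, read by MTT assay, with a stated time of 72 h; a lower number here means a stronger inhibitor, a higher number a weaker inhibitor:
Compound 1, `COc1ccc(-n2ccc(=O)c(C(=O)Nc3ccc(Oc4ccnc5[nH]ccc45)c(F)c3)n2)cc1`, gives > 60000 nM, which is a limit of the assay and not a number.
Compound 2, `COc1ccc(-n2ccc(=O)c(C(=O)Nc3ccc(Oc4ccnc5c4ccn5C)c(F)c3)n2)cc1`, gives > 60000 nM, also a limit of the assay.
Compound 3, `Cc1cc(=O)n(-c2ccccc2OC(F)(F)F)nc1C(=O)Nc1ccc(Oc2ncnc3[nH]ccc23)cc1`, gives 16200 nM.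

Compounds 1 and 2 share one core and differ by methyl in place of hydrogen on an aromatic nitrogen. The size of that step, a step that the two limits leave unreadable from compound 1 to compound 2, cannot be read because of the limit of > 60000 nM in this assay, at which 2 of the 3 values shown sit. Compound 3 carries a different core; the difference between the two cores is not broken down here. Among the three, compound 3 alone yields a number rather than a limit in this assay.

Compound 4, `Cc1cc(=O)n(-c2ccccc2OC(F)(F)F)nc1C(=O)Nc1ccc(Oc2ncnc3c2ccn3C)cc1`, is not yet measured. It differs from compound 3 by methyl in place of hydrogen on an aromatic nitrogen, the same change that turns compound 1 into compound 2, made at the same place.

Since the earlier step left no readable size, the expectation rests on compound 3 alone, whose 16200 nM already sits near the weak end. Compound 4 is expected to give about 22000 nM, within 8000 nM to 60000 nM. This means an expected step of a 1.4-fold higher number from compound 3 to compound 4 (0.13 log units; within the scatter), close to no change in this assay.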

Compound 4, half-maximal inhibitory concentration: 25200 nM
For compound 4 the middle estimate is 1.1-fold (0.06 log units) below the measured one; low and high end bracket the measured number.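

In this assay, methyl in place of hydrogen on the aromatic nitrogen gives a 1.6-fold higher number from compound 3 to compound 4 (0.19 log units; within the scatter), so on this core the two values cannot be told apart. The same change on the other core cannot be read, since compound 1 and compound 2 both sit at a limit of the assay and not at a number: the limit of > 60000 nM in this assay, at which 2 of the 4 values shown sit. The series therefore shows one readable step on one core, which does not show that the change carries over from one core to the other, or that it would stay within the scatter elsewhere.

The compounds shown leave open whether a longer chain on that aromatic nitrogen, such as an ethyl, or a chain ending in an amine, would give a step beyond the scatter in this assay. They also leave open whether the methyl step would keep its size on a further core whose values both come out as numbers.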